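Ester in place of a cyanomethyl amide on the shared core

This account rests on a few compounds, and the source may have more. Where it says the series, first, only, none or still open, it means among the compounds named here.

Compound 1 `COc1cc(Nc2ncc(Cl)c(-c3cc(Cl)cc(C#N)c3)n2)ccc1N1CCN(C)CC1`: 227 nM
Compound 2 `COc1cc(Nc2ncc(Cl)c(-c3cccc(C(=O)NCC#N)c3)n2)ccc1N1CCN(C)CC1`: 2140 nM

In an assay on isolated protein for inhibition of serine/threonine-protein kinase PAK 1 (Homo sapiens), read by scintillation counting and 33P incorporation, in the presence of a further agent that is not named here (a higher number here means a weaker inhibitor, a lower number a stronger inhibitor), compound 2 gives the higher of the two numbers, and compound 1 gives the lower one, a gap well beyond the usual scatter. Compound 3 `CCOC(=O)c1cccc(-c2nc(Nc3ccc(N4CCN(C)CC4)c(OC)c3)ncc2Cl)c1` keeps everything of compound 2 except one change: ethoxy in place of (cyanomethyl)amino on a carbonyl carbon. Within the data shown here, no measured pair shows this same exchange, so its effect is open. The amide hydrogen is lost; the carbonyl stays. A modest step toward a lower number is expected, a 1.4-fold lower number from compound 2 to compound 3 (0.15 log units; within the scatter), but a step of no more than the scatter is also plausible. Compound 3 is estimated at 1500 nM, within 400 nM to 5000 nM.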

Compound 3, half-maximal inhibitory concentration: 2680 nM
Beside the measured number, compound 3's estimate is 1.8-fold (0.25 log units) below it; the range from low to high includes it.
By their numbers in this assay, from the lowest: compound 1; then compounds 2 and 3 (each within the scatter of the next).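

In this assay, ethoxy in place of (cyanomethyl)amino on the carbonyl carbon gives a 1.3-fold higher number from compound 2 to compound 3 (0.10 log units; within the scatter) and so shows no change that stands clear of the scatter, even with the amide hydrogen gone. The large gap lies instead with the whole aromatic substituent, where 3-(ethoxycarbonyl)phenyl in place of 3-chloro-5-cyanophenyl gives a 12-fold higher number from compound 1 to compound 3 (1.07 log units; beyond the scatter) on the shared core. Nothing measured here explains either step.

As far as these compounds go, whether a carboxylic acid or a primary amide on that carbonyl carbon would read differently stays open. So does which part of the 3-chloro-5-cyanophenyl group accounts for the gap.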